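The compounds below may be only part of what the source reports. "The series", "measured", "known", "first", "only" and "open" are said of these compounds alone.

In a functional assay on OCI-Ly3 cells (Homo sapiens) for inhibition, read by CellTiter-Glo, with stated times of 48 h and 96 h (on this read-out higher numbers stand for weaker inhibition of growth and lower numbers for stronger inhibition of growth), compound 1 (`CC(C)[C@H](NC(=O)OCc1ccccc1)C(=O)N1CCC[C@H]1C(=O)N(C)[C@@H](CCCNC(=N)N)C(=O)CF`) has the entry "not determined" (no result reported), so it offers no number for comparison. Compound 2 (`CC(C)[C@H](NC(=O)c1ccccc1)C(=O)N1CCC[C@H]1C(=O)N[C@@H](CCCNC(=N)N)C(=O)CF`) gives 660 nM in this assay. Among the compounds with values here, this is the only number available, and compound 2 therefore cannot yet be ranked against another compound. Compound 3 (`CC(C)[C@H](NC(=O)c1ccc(Br)cc1)C(=O)N1CCC[C@H]1C(=O)N[C@@H](CCCNC(=N)N)C(=O)CF`) keeps the rest of compound 2 and alters only its benzoyl group, which becomes (4-bromophenyl)carbonyl. The change is bromo in place of hydrogen on an aromatic carbon, with bromo in place of hydrogen on an aromatic carbon, para to a large group. Within the data shown here, no measured pair shows the effect of such a change, so the expectation rests on its being a single-atom substitution. No step beyond the scatter is expected in this assay, and no direction is favoured. The estimated step of a 1.1-fold lower number from compound 2 to compound 3 (0.04 log units; within the scatter) is accordingly small. For compound 3 the expected value is 600 nM, with an estimated range of 200 nM to 1800 nM.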

Compound 3, concentration for 50% growth inhibition: 130 nM
The estimate for compound 3 lay 4.6-fold (0.66 log units) above the measured number; measured number outside the range, below it.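

In this assay, putting bromo in place of hydrogen on the aromatic carbon para to a large group gives a 5.1-fold lower number from compound 2 to compound 3 (0.71 log units; beyond the scatter) and so moves the number beyond the scatter. This place on the six-membered aromatic ring is therefore not indifferent to substitution: one added heavy atom, with no ring, no hydrogen-bond donor or acceptor and no net charge, is enough to shift growth inhibition towards the stronger side. Nothing available explains why this single change has such an effect. As far as these compounds go, whether chloro, methoxy, an amine or a carboxylic acid at this place would shift the number in the same direction remains open, as does the effect of bromo elsewhere on the ring. Within the data shown here, no step to compound 1 can be read, as it has no number.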